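Methoxy for Chloro on a Biaryl Thiophene Amidine

A few compounds are considered here, and "the series" means these few. Any claim that something is new, unique, unknown or untested is made for them only; others in the source may bear on it.

Measured compounds:
- compound 1, `N=C(N)c1ccc(-c2ccc(-c3ccc(F)cc3)s2)cc1`: 1560 nM
- compound 2, `N=C(N)c1ccc(-c2ccc(-c3ccc(Cl)cc3)s2)cc1F`: "not determined" (no result reported)
- compound 3, `COc1cc(OC)cc(-c2ccc(-c3ccc(C(=N)N)c(F)c3)s2)c1`: "not determined" (no result reported)

Compound 1 was tested in a functional assay on MDA-MB-231 cells (Homo sapiens) for inhibition, read by sulforhodamine B assay, with a stated time of 48 h (on this read-out higher numbers stand for weaker inhibition of growth and lower numbers for stronger inhibition of growth), and gives 1560 nM. For compound 2 the same test returned "not determined" (no result reported), and for compound 3 it returned "not determined" (no result reported), so the strength of neither of these two compounds is known from the data at hand. Compound 2 therefore stands without a value of its own; the only measured point in this set is compound 1.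

Compound 4, `COc1ccc(-c2ccc(-c3ccc(C(=N)N)c(F)c3)s2)cc1`, has not yet been measured. It differs from compound 2 in one place: methoxy in place of chloro on an aromatic carbon.

Without a value for compound 2 and without any step between two measured compounds, the size and direction of the change from compound 2 to compound 4 in this assay cannot be read from the numbers. The expectation rests on compound 1 alone, whose value of 1560 nM marks the only level seen so far, and the change is treated as likely to stay within the usual scatter of that level.

Compound 4 is therefore expected to give about 2000 nM in this assay, estimated within a range from 500 nM to 8000 nM.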

Compound 4, concentration for 50% growth inhibition: 2750 nM
For compound 4 the middle estimate is 1.4-fold (0.14 log units) below the measured one, within the range that was stated.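

Among the compounds shown here, no step from compound 2 to compound 4 can be read: compound 2 stands without a single number in this assay. The compounds shown leave open how putting methoxy in place of chloro changes growth inhibition on this core. No supporting data bear on the value of compound 4.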